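Ureas on a fluorophenoxy-cyclohexyl core: weak cytotoxicity

This account rests on a few compounds, and the source may have more. Where it says the series, first, only, none or still open, it means among the compounds named here.

Compound 1 `O=C(Nc1ccc(F)cc1)N[C@H]1CC[C@H](Oc2ccc(F)cc2)CC1` was tested in a functional assay on CRL2813 cells (Homo sapiens) for cytotoxicity, read by sulforhodamine B assay, with a stated time of 5 days (a lower number here means a stronger inhibitor, a higher number a weaker inhibitor), where compound 1 gives 20000 nM. Compound 2 `CSc1ccccc1NC(=O)N[C@H]1CC[C@H](Oc2ccc(F)cc2)CC1` carries a 2-(methylsulfanyl)phenyl on the urea nitrogen in place of the 4-fluorophenyl. For compound 2 this assay reports only a limit, > 20000 nM. Compound 3 `COc1ccccc1NC(=O)N[C@H]1CC[C@H](Oc2ccc(F)cc2)CC1` carries a 2-methoxyphenyl in that position. For compound 3 this assay likewise reports only a limit, > 20000 nM. The step of a number no lower from compound 1 to compound 2 (the limit leaves the size open) and the step of a number no lower from compound 1 to compound 3 (the limit leaves the size open) both run toward weaker inhibition, but their size is hidden by the limit of > 20000 nM in this assay, at which 2 of the 3 values shown sit. The step that the two limits leave unreadable from compound 2 to compound 3 cannot be read at all, since both values are limits. Compound 3 therefore stands at the weak end of what has been measured, with no number of its own.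

Compound 4 `O=C(Nc1cccc([N+](=O)[O-])c1)N[C@H]1CC[C@H](Oc2ccc(F)cc2)CC1` differs from compound 3 by 3-nitrophenyl in place of 2-methoxyphenyl on an amide-type nitrogen. Going by the values given here, none of the measured steps bears directly on this change, and the two that touch the same position are hidden behind the limit. Compound 3 itself is only known as a limit, so the step of a number no higher from compound 3 to compound 4 (the limit leaves the size open) is a guess rather than an expectation drawn from a readable trend. Compound 4 is expected to give 20000 nM in this assay, within 7000 nM to 60000 nM, and it is likely that only a limit is reported again.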

Compound 4, half-maximal inhibitory concentration: 6700 nM
Compound 4: the middle estimate sits 3.0-fold (0.47 log units) above what was measured, outside the stated range (below it).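

With 3-nitrophenyl on the amide-type nitrogen, this position gives its first change toward stronger inhibition in this assay that can be sized, and the step is modest but beyond the usual scatter: a 3.0-fold lower number from compound 1 to compound 4 (0.47 log units; beyond the scatter). Compound 4 also parts from the two compounds with a 2-substituted phenyl, with an at least 2.9-fold lower number from compound 3 to compound 4 (0.47 log units; beyond the scatter) and an at least 2.9-fold lower number from compound 2 to compound 4 (0.47 log units; beyond the scatter), so the group on the urea nitrogen can move the read-out even though the earlier changes at this position showed only limits. Both of these last steps are floors and their full size cannot be read, and the same holds for the steps among compounds 1, 2 and 3 that end in a limit: the limit of > 20000 nM in this assay, at which 2 of the 4 values shown sit.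

The compounds shown leave open whether the lower number belongs to the nitro group itself, or whether an amine, a nitrile or a carboxylic acid on the same phenyl would give a similar step. They also leave open whether a change at this position alone can take the series much further than compound 4, since the fluorophenoxy side of the shared core stays the same throughout.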